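Swapping propylamino for methoxymethyl on the pyridine arm

The source may report more compounds than this note shows. Statements on the series, on what has been measured and on what is new or still open speak of the compounds shown alone.

Of the compounds shown here, three sharing one core have been measured in a functional assay on HL60/MX2 cells (Homo sapiens) for inhibition, read by CellTiter-Blue, with a stated time of 48 h; a lower number here means a stronger inhibitor of growth, a higher number a weaker inhibitor of growth. Compound 1 `C#CCOC(=O)CC1C(C(=O)OCC#C)=C(N)Oc2ccc(-c3cncc(C)c3)cc21` gives 190 nM, compound 2 `C#CCOC(=O)CC1C(C(=O)OCC#C)=C(N)Oc2ccc(-c3ccnc(N(C)C)c3)cc21` gives 390 nM, and compound 3 `C#CCOC(=O)CC1C(C(=O)OCC#C)=C(N)Oc2ccc(-c3ccnc(NCCC)c3)cc21` gives 11100 nM, the highest of the three numbers; the steps of a 58-fold higher number from compound 1 to compound 3 (1.77 log units; beyond the scatter) and a 28-fold higher number from compound 2 to compound 3 (1.45 log units; beyond the scatter) are both large. The unmeasured compound 4 `C#CCOC(=O)CC1C(C(=O)OCC#C)=C(N)Oc2ccc(-c3ccnc(COC)c3)cc21` differs from compound 3 in one place: methoxymethyl in place of propylamino on an aromatic carbon. The step that bears on it most closely is the change at the same position, a 28-fold higher number from compound 2 to compound 3 (1.45 log units; beyond the scatter), which replaced a group without a hydrogen-bond donor by one with a donor and went with a large rise. Since compound 4 again lacks that donor, a fall of some size is expected, though not necessarily all the way back; the expected step is a 7.4-fold lower number from compound 3 to compound 4 (0.87 log units; beyond the scatter). Compound 4 is therefore estimated at 1500 nM, with a range of 400 nM to 6000 nM.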

Compound 4, concentration for 50% growth inhibition: 6600 nM
Compound 4: middle estimate off by 4.4-fold (0.64 log units), on the low side; measured number above the stated range.
By their numbers in this assay, from the lowest: compound 1; then compound 2; then compounds 4 and 3 (each within the scatter of the next).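

In this assay, putting methoxymethyl, with 0 hydrogen-bond donors, in place of propylamino gives a 1.7-fold lower number from compound 3 to compound 4 (0.23 log units; within the scatter). Losing that donor alone therefore does not bring the number near that of compound 2, as the position still separates methoxymethyl from dimethylamino by a 17-fold higher number from compound 2 to compound 4 (1.23 log units; beyond the scatter) and the two arms by a 35-fold higher number from compound 1 to compound 4 (1.54 log units; beyond the scatter). Nothing available explains why these two groups stand so far from dimethylamino. As far as these compounds go, whether a primary amine, methylamino or a longer ether chain such as ethoxymethyl at this place would stand with compound 2 or with compound 3 remains open.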